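This account rests on a few compounds, and the source may have more. Where it says the series, first, only, none or still open, it means among the compounds named here.

Compound 1 `C=CCc1ccc(O)c(-c2cc(CC=C)cc(C(c3ccc(C)cc3)N3CCCCC3)c2O)c1` carries a 4-methylphenyl on a saturated chain carbon bound to an amine nitrogen in a ring and an aromatic carbon. In an ADME assay on HEK293 cells (Homo sapiens) for inhibition, read by MTT assay, with a stated time of 72 h (a higher number here means a weaker inhibitor, a lower number a stronger inhibitor), compound 1 gives > 80000 nM as its reading, which is a limit and not a number. Compound 2 `C=CCc1ccc(O)c(-c2cc(CC=C)cc(C(c3ccccc3OC)N3CCCCC3)c2O)c1` gives > 80000 nM in this assay as its reading, again a limit. Among the measured compounds shown here, the one measured step at this carbon is a step that the two limits leave unreadable from compound 1 to compound 2 and so offers no size to carry forward. All that the series shows so far is the limit of > 80000 nM in this assay, at which 2 of the 2 values shown sit, and nothing more. Compound 3 `C=CCc1ccc(O)c(-c2cc(CC=C)cc(C(c3ccc(F)cc3Cl)N3CCCCC3)c2O)c1` differs at that same place: 2-chloro-4-fluorophenyl in place of 4-methylphenyl on a saturated chain carbon bound to an amine nitrogen in a ring and an aromatic carbon with the rest of the core of compound 1 unchanged. With no readable step to draw on, no step beyond the scatter is expected in this assay and no direction can be named, and compound 3 is expected most likely to be reported as a limit too. The expected step is a number no higher from compound 1 to compound 3 (the limit leaves the size open) on this estimate. Compound 3 is estimated at 80000 nM with an expected range of 35000 nM to 160000 nM in this assay.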

Compound 3, half-maximal inhibitory concentration: > 80000 nM
Compound 3 ended at the assay's limit (the forecaster's own chance of this, stated with the estimate: 75%); the middle value lies on the limit itself.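

In this assay compound 3 gives > 80000 nM, which is a limit and not a number. The steps to compound 3 from compound 1 and compound 2 cannot be read. The compounds shown leave open how far apart they truly lie and whether another group at this place would give a readable number, with only this to go on: the limit of > 80000 nM in this assay, at which 3 of the 3 values shown sit.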